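Swapping the basic side chain for a plain alkyl chain

A few compounds are considered here, and "the series" means these few. Any claim that something is new, unique, unknown or untested is made for them only; others in the source may bear on it.

Measured compounds and their results:
Compound 1, `CN(C(=O)CNC(=O)CN)c1ccc(Cl)cc1C(=O)c1ccccc1Cl`, gives 0.58 mg/kg in a functional assay on the whole organism for antagonist activity, with Mus musculus as the target; a lower number here means that less compound is needed, a higher number that more compound is needed for the effect.
Compound 2, `CC(C)C(=O)NCC(=O)N(C)c1ccc(Cl)cc1C(=O)c1ccccc1Cl`, gives 6 mg/kg in this assay.
Compound 3, `CCN(CC)CC(=O)NCC(=O)N(C)c1ccc(Cl)cc1C(=O)c1ccccc1Cl`, gives 2.2 mg/kg in this assay.

Compound 3 stands second highest of the three numbers: its nearest neighbour is compound 2, reached by a 2.7-fold lower number from compound 2 to compound 3 (0.44 log units; beyond the scatter), and its furthest is compound 1, with a 3.8-fold higher number from compound 1 to compound 3 (0.58 log units; beyond the scatter).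

Compound 4, `CCCCCCC(=O)NCC(=O)N(C)c1ccc(Cl)cc1C(=O)c1ccccc1Cl`, has not yet been measured. Its change from compound 3 is pentyl in place of diethylamino on a saturated chain carbon bound to a carbonyl carbon. Within the data shown here, two measured steps bear on this. The step of a 10-fold higher number from compound 1 to compound 2 (1.01 log units; beyond the scatter) shows that replacing an amine-bearing group with a plain alkyl group raised the number strongly, and a 2.7-fold lower number from compound 2 to compound 3 (0.44 log units; beyond the scatter) shows that introducing an amine lowered it modestly. The change to compound 4 again removes the amine and leaves an alkyl chain, so a modest rise in this assay is expected, roughly undoing the second of these steps.

Compound 4 is therefore estimated at 5.5 mg/kg, with a likely range from 2.5 mg/kg to 12 mg/kg, which means an expected step of a 2.5-fold higher number from compound 3 to compound 4 (0.40 log units; beyond the scatter).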

Compound 4, dose for half-maximal effect: 1.9 mg/kg
Compound 4: the middle estimate sits 2.9-fold (0.46 log units) above what was measured, outside the stated range (below it).
By their numbers in this assay, from the lowest: compound 1; then compounds 4 and 3 (each within the scatter of the next); then compound 2.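

In this assay, a pentyl group on this saturated chain carbon cannot be told apart from diethylamino (a 1.2-fold lower number from compound 3 to compound 4 (0.06 log units; within the scatter)), so among these compounds the nitrogen of compound 3 is not required for a number at this level. The plain alkyl groups do not behave alike either: hexyl in place of isopropyl on the carbonyl carbon gives a clear change (a 3.2-fold lower number from compound 2 to compound 4 (0.50 log units; beyond the scatter)), so the low activity of compound 2 cannot be read as a general result of having no amine. Compound 1, with its simple amino group, still has the lowest number of the four (a 3.3-fold higher number from compound 1 to compound 4 (0.52 log units; beyond the scatter)). Going by these compounds, whether a longer chain or a carboxylic acid at this place would stay close to compound 4 or move towards compound 1 remains open. Nothing shown here gives a reason for any of these steps.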